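The compounds below may be only part of what the source reports. "The series", "measured", "known", "first", "only" and "open" are said of these compounds alone.

Measured so far in a functional assay on MCF7 cells (Homo sapiens) for cytotoxicity, read by sulforhodamine B assay, with a stated time of 48 h; on this read-out lower numbers stand for stronger inhibition and higher numbers for weaker inhibition:

Compound 1, `CC1(C)CNC(=O)c2cc(-c3ccc([N+](=O)[O-])cc3)n(-c3ccc(Br)cc3)c2C1`: > 100000 nM
Compound 2, `CC1(C)CNC(=O)c2cc3n(c2C1)CCc1ccccc1-3`: > 100000 nM

In this assay compound 2 gives > 100000 nM, which is a limit of the assay and not a number. Compound 1 gives > 100000 nM, also a limit and not a number. Neither compound therefore supplies a measured potency, and the record so far consists of the limit of > 100000 nM in this assay, at which 2 of the 2 values shown sit.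

Compound 3, `CC1(C)CNC(=O)c2cc3n(c2C1)CCc1cc(Cl)ccc1-3`, differs from compound 2 by one change: chloro in place of hydrogen on an aromatic carbon of a six-membered aromatic ring of carbon only, part of a fused or bridged system of four rings, meta to a fused ring and para to a fused ring (chloro in place of hydrogen on an aromatic carbon). Among the compounds with values here, no measured pair shows what this change does in this assay. The expectation rests only on compound 2 at its limit of > 100000 nM. The expected size of the change is no step beyond the scatter, and another report as a limit is likely. The estimated change is a number no higher from compound 2 to compound 3 (the limit leaves the size open). For compound 3 the expected value is 100000 nM, with an estimated range from 30000 nM to 200000 nM.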

Compound 3, half-maximal inhibitory concentration: > 100000 nM
Compound 3: a limit, no number; the forecaster's own chance of this, stated with the estimate: 70%; the middle value sits exactly at the limit.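

In this assay compound 3 gives > 100000 nM, which is a limit and not a number. Compound 2 also stands at a limit, so no step can be read between compound 2 and compound 3. The compounds shown leave open whether any change to the shared core would give a measured number: the limit of > 100000 nM in this assay, at which 3 of the 3 values shown sit.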